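The compounds below may be only part of what the source reports. "The series", "measured", "known", "first", "only" and "open" are said of these compounds alone.

Measured compounds:
Compound 1 `CCOC(=O)CNC(=O)c1cccc2nc(OCC)n(Cc3ccc(-c4ccccc4-c4nnn[nH]4)cc3)c12`: in an assay on isolated protein for inhibition of NEDD8-activating enzyme E1 regulatory subunit (Homo sapiens), read by Western blot, with stated times of 10 min and 30 min, tested at 25 uM (a higher number here means more inhibition at the concentration tested (going by the name of the read-out), a lower number less inhibition), compound 1 gives 46.5%.
Compound 2 `CCOc1nc2cccc(C(=O)Nc3ccccc3)c2n1Cc1ccc(-c2ccccc2-c2nnn[nH]2)cc1`: in this assay compound 2 gives 34.6%.
Compound 3 `CCOc1nc2cccc(C(=O)Nc3ccc(F)cc3)c2n1Cc1ccc(-c2ccccc2-c2nnn[nH]2)cc1`: in this assay compound 3 gives 45.3%.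

Compound 3 stands second highest of the three numbers. Its nearest neighbour is compound 1, and the step of a number 1.2 percentage points lower from compound 1 to compound 3 (within the scatter) lies within the scatter, so the two cannot be ordered. Its furthest neighbour is compound 2, and the step of a number 10.7 percentage points higher from compound 2 to compound 3 (beyond the scatter) is modest but beyond the scatter.

Compound 4 `CCOc1nc2cccc(C(=O)Nc3ccc(S(N)(=O)=O)cc3)c2n1Cc1ccc(-c2ccccc2-c2nnn[nH]2)cc1` differs from compound 3 by sulfamoyl in place of fluoro on an aromatic carbon. Among the compounds with values here, the one measured step at this position is a number 10.7 percentage points higher from compound 2 to compound 3 (beyond the scatter), which shows that a change at this aromatic carbon can move the number by a modest amount. Within the data shown here, no measured compound carries a sulfamoyl anywhere, so the direction of the step to compound 4 is not anchored by data; the two amide-side steps, a number 11.9 percentage points lower from compound 1 to compound 2 (beyond the scatter) and a number 1.2 percentage points lower from compound 1 to compound 3 (within the scatter), show only that changes at this end of the molecule have so far stayed modest.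

Compound 4 is therefore expected to land near 45%, with a range from 25% to 65%. The expected step is a number 0.3 percentage points lower from compound 3 to compound 4 (within the scatter), no clearer than the scatter in either direction.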

Compound 4, a percentage reported as inhibition, at one concentration (the size of the read-out at that concentration, not a potency): 60.9%
For compound 4 the middle estimate is 15.9 percentage points below the measured one; the measured number falls inside the stated range.
By their numbers in this assay, from the lowest: compound 2; then compounds 3 and 1 (each within the scatter of the next); then compound 4.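

In this assay, the aromatic carbon para to a large group accepts sulfamoyl, and the result is the clearest gain yet at this position: the step from fluoro is a number 15.6 percentage points higher from compound 3 to compound 4 (beyond the scatter) and the step from hydrogen is a number 26.3 percentage points higher from compound 2 to compound 4 (beyond the scatter). Within the data shown here, the earlier compounds showed only that fluoro lifts the number over hydrogen, and fluoro did not separate from the (ethoxycarbonyl)methyl group on the amide nitrogen, whereas 4-sulfamoylphenyl does, with a number 14.4 percentage points higher from compound 1 to compound 4 (beyond the scatter) as the step. Nothing in the data shown accounts for this gain.

The compounds shown leave open whether a methylsulfonyl group or a carboxylic acid on the same carbon would give a similar number, or whether sulfamoyl itself is needed. They also leave open whether the gain would hold with sulfamoyl elsewhere on that ring, and whether it would hold at other concentrations.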